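This account rests on a few compounds, and the source may have more. Where it says the series, first, only, none or still open, it means among the compounds named here.

Measured compounds:
- compound 1, `Cc1cc(NS(=O)(=O)c2ccc(N/C(S)=N\c3ccnc4cc(C(F)(F)F)ccc34)cc2)on1`, with 27300 nM in a functional assay on HT-1080 cells (Homo sapiens) for antiproliferative activity, read by sulforhodamine B assay, with a stated time of 48 h; a lower number here means a stronger inhibitor, a higher number a weaker inhibitor
- compound 2, `O=S(=O)(Nc1ncccn1)c1ccc(N/C(S)=N\c2ccnc3cc(C(F)(F)F)ccc23)cc1`, with 29100 nM in this assay

Compound 1 has the lower of the two numbers, but the step of a 1.1-fold higher number from compound 1 to compound 2 (0.03 log units; within the scatter) lies within the scatter, so the two measured compounds are not told apart by this assay; both are weak inhibitors on the scale shown.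

Compound 3, `COc1cc(NS(=O)(=O)c2ccc(N/C(S)=N\c3ccnc4cc(C(F)(F)F)ccc34)cc2)nc(OC)n1`, is the next compound to be tested in this assay. It differs from compound 1 in one place: 2,6-dimethoxypyrimidin-4-yl in place of 3-methyl-1,2-oxazol-5-yl on a sulfonamide nitrogen

Within the data shown here, the single measured step bears directly on this change. It also exchanged the ring on the sulfonamide nitrogen, replacing a five-membered by a six-membered heteroaromatic ring, and the number moved only by a 1.1-fold higher number from compound 1 to compound 2 (0.03 log units; within the scatter). Among the measured compounds shown here, with that as the only guide, the expected step from compound 1 to compound 3 is none beyond the scatter, that is a 1.0-fold higher number from compound 1 to compound 3 (0.01 log units; within the scatter). Compound 3 is therefore estimated to give 28000 nM in this assay, with a range from 12000 nM to 65000 nM.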

Compound 3, half-maximal inhibitory concentration: 29500 nM
Compound 3: the middle estimate sits 1.1-fold (0.02 log units) below what was measured, and the stated range covers the measured number.
By their numbers in this assay, from the lowest: compounds 1, 2 and 3 (each within the scatter of the next).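

Moving to the 2,6-dimethoxypyrimidin-4-yl group gives a 1.1-fold higher number from compound 1 to compound 3 (0.03 log units; within the scatter) in this assay even though the entering group has more heavy atoms and more hydrogen-bond acceptors than 3-methyl-1,2-oxazol-5-yl. Set against the bare pyrimidin-2-yl group, the same substituent gives a 1.0-fold higher number from compound 2 to compound 3 (0.01 log units; within the scatter) and so adds a second comparison at this position, showing that the methoxy-bearing ring on the sulfonamide nitrogen is not told apart from either earlier ring, and all three compounds remain together as weak inhibitors on the scale shown. Nothing measured here accounts for this lack of separation.

Going by these compounds, it remains open whether the number would stay put with a non-aromatic group on the sulfonamide nitrogen, such as a morpholine or a plain methyl, or with a heteroaromatic ring carrying a carboxylic acid or a primary amine. Also open, on these data alone, is whether activity answers to anything outside this position, since all three compounds share the rest of the core, including its trifluoromethyl group.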